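This account rests on a few compounds, and the source may have more. Where it says the series, first, only, none or still open, it means among the compounds named here.

Going by the values given here, compound 1 `COc1cc(-c2nnc3n2NC(c2ccco2)C(C(=O)c2ccc(F)c(F)c2)S3)cc(OC)c1OC` is one of three compounds measured in a functional assay on PC-3 cells (Homo sapiens) for cytotoxicity, read by MTT assay, with a stated time of 48 h (a higher number here means a weaker inhibitor, a lower number a stronger inhibitor), where compound 1 gives 36000 nM. Compound 3 `COc1cc(-c2nnc3n2NC(c2cccs2)C(C(=O)c2ccc(Cl)cc2)S3)cc(OC)c1OC` gives 32500 nM, and the two numbers lie within the scatter of each other. Among the compounds with values here, compound 2 `COc1cc(-c2nnc3n2NC(c2ccco2)C(C(=O)C2CC2)S3)cc(OC)c1OC` gives 95200 nM, the highest of the three, and the only step that differs in one place, a 2.6-fold higher number from compound 1 to compound 2 (0.42 log units; beyond the scatter), leads to that compound. Compound 4 `COc1cc(-c2nnc3n2NC(c2ccco2)C(C(=O)c2ccc(C(F)(F)F)cc2)S3)cc(OC)c1OC` has not yet been measured. It differs from compound 1 in one place: 4-(trifluoromethyl)phenyl in place of 3,4-difluorophenyl on a carbonyl carbon. Within the data shown here, the step from compound 1 to compound 2 is the only measured step at the same carbonyl carbon, and it exchanged a six-membered aromatic ring of carbon only for cyclopropyl; in compound 4 a six-membered aromatic ring of carbon only remains, so that step shows only that this place can shift the number and says little about exchanging one such ring for another. Among the measured compounds shown here, with no measured step of that kind, the expected step of a 1.1-fold higher number from compound 1 to compound 4 (0.05 log units; within the scatter) is none beyond the scatter. Compound 4 is therefore estimated at 40000 nM, between 18000 nM and 90000 nM.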

Compound 4, half-maximal inhibitory concentration: 77500 nM
Compound 4: middle estimate off by 1.9-fold (0.29 log units), on the low side, and the stated range covers the measured number.
By their numbers in this assay, from the lowest: compounds 3 and 1 (each within the scatter of the next); then compounds 4 and 2 (each within the scatter of the next).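

In this assay the exchange of one six-membered aromatic ring of carbon only for another on the carbonyl carbon is not silent: a 2.2-fold higher number from compound 1 to compound 4 (0.33 log units; beyond the scatter) shows that the number at this place depends on what the ring carries, not only on whether a ring is present. The cyclopropyl group and the 4-(trifluoromethyl)phenyl group cannot be told apart here, as a 1.2-fold lower number from compound 2 to compound 4 (0.09 log units; within the scatter) shows, so keeping an aromatic ring does not by itself hold the number near that of compound 1. Nothing measured here bears on the reason for these steps.

As far as these compounds go, it remains open how a phenyl ring carrying an amine, a carboxylic acid or a single fluorine would compare with compound 1. Also open, from the compounds shown here alone, is whether a longer alkyl chain on the carbonyl carbon would fall with compound 2 and compound 4.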